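This account rests on a few compounds, and the source may have more. Where it says the series, first, only, none or still open, it means among the compounds named here.

Measured in a functional assay on Hs-578T cells (Homo sapiens) for antiproliferative activity; a lower number here means a stronger inhibitor of growth, a higher number a weaker inhibitor of growth:

Compound 1 (`COCCCCCCCCCCCCCCC/C=C1/CC(CO)(COC(=O)C(C)(C)C)OC1=O`) gives 6.77 ug/mL
Compound 2 (`COC(=O)CCCCCCCCCCCCCC/C=C1\CC(CO)(COC(=O)C(C)(C)C)OC1=O`) gives > 10 ug/mL

Compound 2 stands at the limit of > 10 ug/mL in this assay, at which 1 of the 2 values shown sits, and so has a limit, not a number. Compound 3 (`CC(C)(C)C(=O)OCC1(CO)C/C(=C\CCCCCCCCCCCO)C(=O)O1`), not yet measured, differs from compound 2 through hydroxy in place of 3-(methoxycarbonyl)propyl on a saturated chain carbon, ten or more bonds along the chain from a double-bonded chain carbon and in nothing else. In this assay, among the compounds with values here, the only firm number is that of compound 1 at 6.77 ug/mL and no measured step shows what this change does. The expected change is small and toward stronger growth inhibition, with an at least 1.1-fold lower number from compound 2 to compound 3 (0.04 log units; that floor lies within the scatter) as the estimate. The estimated value for compound 3 is 9 ug/mL with an expected range from 4 ug/mL to 20 ug/mL around it.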

Compound 3, concentration for 50% growth inhibition: > 10 ug/mL
Compound 3: no number, only a limit; the forecaster's own chance of this, stated with the estimate: 45%; at least 1.1-fold (0.04 log units) between middle value and limit.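

Within the data shown here, no step from compound 2 to compound 3 can be read, because both compounds stop at the same limit and neither gives a number: the limit of > 10 ug/mL in this assay, at which 2 of the 3 values shown sit. From the compounds shown here alone, what hydroxy in place of 3-(methoxycarbonyl)propyl does to growth inhibition stays open.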